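Two inactive amides and a third with a longer side chain

The compounds below may be only part of what the source reports. "The series", "measured", "known", "first", "only" and "open" are said of these compounds alone.

Compound 1, with the structure `C=CCONC(=O)Cn1ccc(C(=O)NCC(=O)N[C@@H](CC(C)C)C(=O)O)c1`, and compound 2, with the structure `C=CCONC(=O)Cn1ccc(C(=O)N[C@@H](C)C(=O)N[C@H](C(=O)O)C(C)C)c1`, share a common core and differ only in the short peptide-like chain attached to it. In a functional assay on RAW264.7 cells (Mus musculus) for inhibition, read by microscopy and resazurin assay, with a stated time of 72 h (on this read-out higher numbers stand for weaker inhibition and lower numbers for stronger inhibition), compound 1 gives > 128000 nM, which is a limit of the assay rather than a number. In this assay compound 2 likewise gives > 128000 nM, again a limit of the assay and not a measured number. For the measured compounds named here, compound 2 therefore stands at the top of what is reported, and the limit of > 128000 nM in this assay, at which 2 of the 2 values shown sit, shows that every value so far sits there.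

Compound 3, with the structure `C=CCONC(=O)Cn1ccc(C(=O)N[C@@H](C)C(=O)N[C@@H](CC(C)C)C(=O)O)c1`, is the next step from compound 2. The change is isobutyl in place of isopropyl on a saturated chain carbon bound to an amide-type nitrogen and a carbonyl carbon. Going by the values given here, because both measured compounds sit at the limit of > 128000 nM in this assay, at which 2 of the 2 values shown sit, no step between measured compounds is available to show how this assay responds to such a change. The expectation is that the step from compound 2 to compound 3 is a step that the limit leaves unreadable from compound 2 to compound 3, with no move beyond the scatter. Compound 3 is thus expected to give about 200000 nM, in the range 60000 nM to 600000 nM, most likely reported only as a limit.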

Compound 3, half-maximal inhibitory concentration: > 128000 nM
Compound 3 was reported as a limit; the forecaster's own chance of this, stated with the estimate: 85%; the middle value does not contradict the limit.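

In this assay compound 3 gives > 128000 nM, a limit of the assay and not a number, so its steps from compound 1 and from compound 2 cannot be read. All three compounds share one reading: the limit of > 128000 nM in this assay, at which 3 of the 3 values shown sit.

The compounds shown leave open whether any of these peptide-like chains gives a measurable inhibition in this assay, and how large the effect of each change is.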